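A few compounds are considered here, and "the series" means these few. Any claim that something is new, unique, unknown or untested is made for them only; others in the source may bear on it.

Compound 1 `O=C(O)CCc1ccc(NCc2ccc(Cl)cc2)cc1` and compound 2 `O=C(O)CCc1ccc(NCc2ccc(C(=O)O)cc2)cc1` share the same core and differ in a single group on the outer ring. In a functional assay on CHO cells for agonist activity at Free fatty acid receptor 1 (Homo sapiens), read by reporter gene assay (on this read-out higher numbers stand for larger maximal responses and lower numbers for smaller maximal responses), compound 1 gives 111%, whereas compound 2 gives 9%, the lower of the two numbers recorded so far. Compound 3 `N#Cc1ccc(CNc2ccc(CCC(=O)O)cc2)cc1` has not yet been measured; it differs from compound 2 by cyano in place of carboxy on an aromatic carbon. For the measured compounds named here, only one measured step bears on this change: when carboxy took the place of chloro on an aromatic carbon, the result was a number 102 percentage points lower from compound 1 to compound 2 (beyond the scatter), a large fall. Because the step of a number 102 percentage points lower from compound 1 to compound 2 (beyond the scatter) came with the carboxy entering, and compound 3 takes the carboxy away again while putting cyano rather than chloro in its place, the expected step is a number 61 percentage points higher from compound 2 to compound 3 (beyond the scatter), upward and beyond the scatter. Compound 3 is therefore estimated at 70%, with a range from 20% to 110%.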

Compound 3, largest response reached (reported as percent of maximum), in percent of the reference or control that the assay uses: 49%
Compound 3: middle estimate off by 21 percentage points, on the high side, within the range that was stated.
By their numbers in this assay, from the lowest: compound 2; then compound 3; then compound 1.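

In this assay, this position on the outer ring does not simply split into chloro as good and carboxy as poor. Cyano gives an intermediate result, with a number 40 percentage points higher from compound 2 to compound 3 (beyond the scatter) and a number 62 percentage points lower from compound 1 to compound 3 (beyond the scatter). Both steps are large and beyond the scatter, so the three groups give three clearly separate maximal responses, and removing the carboxy recovers only part of the response seen with chloro. The carboxy that leaves counts one hydrogen-bond donor and the cyano that enters counts none, but no measurement here connects that difference, or any other feature of these groups, with the change in response.

The compounds shown leave open how a fluoro, a methoxy or an amine at this position would rank against these three groups. They also leave open whether the same order would hold if the propanoic acid chain of the shared core were replaced by a longer chain.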